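A few compounds are considered here, and "the series" means these few. Any claim that something is new, unique, unknown or untested is made for them only; others in the source may bear on it.

The series shares one core, bearing two amino groups and a phenyl group, and varies only the group attached through an oxygen or a nitrogen. Compound 1 `Nc1cc(N)c2nc(-c3ccccc3)c(Oc3ccc(Cl)c(Cl)c3)nc2c1` gives 31600 nM in a functional assay on U-251 cells (Homo sapiens) for inhibition, read by sulforhodamine B assay, with a stated time of 48 h; on this read-out higher numbers stand for weaker inhibition of growth and lower numbers for stronger inhibition of growth. Compound 2 `COc1ccc(CNc2nc3cc(N)cc(N)c3nc2-c2ccccc2)cc1OC` gives 38900 nM in this assay, the highest of the three numbers, with compound 1 within the scatter of it and compound 3 the furthest from it. Among the compounds with values here, compound 3 `COc1cc(CNc2nc3cc(N)cc(N)c3nc2-c2ccccc2)cc(OC)c1OC` gives 6310 nM in this assay; the step of a 6.2-fold lower number from compound 2 to compound 3 (0.79 log units; beyond the scatter) is the only measured step and is modest.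

Compound 4 `Nc1cc(N)c2nc(-c3ccccc3)c(NCc3ccc(F)cc3)nc2c1` differs from compound 2 by 4-fluorophenyl in place of 3,4-dimethoxyphenyl on a saturated chain carbon bound to a nitrogen on an aromatic ring. The measured step bears on it only indirectly: it shows that a change on this same ring can move the number beyond the scatter, but it adds a methoxy rather than replacing both methoxy groups with a fluorine, so the direction for compound 4 is not told by the data. Compound 4 is therefore expected to give a number close to that of compound 2, with the step of a 1.3-fold lower number from compound 2 to compound 4 (0.11 log units; within the scatter) expected to lie within or only slightly beyond the scatter. The estimate for compound 4 in this assay is 30000 nM, with a range from 9000 nM to 100000 nM.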

Compound 4, concentration for total growth inhibition: 3160 nM
Estimate against measurement, compound 4: 9.5-fold (0.98 log units) above, outside the stated range (below it).
By their numbers in this assay, from the lowest: compounds 4 and 3 (each within the scatter of the next); then compounds 1 and 2 (each within the scatter of the next).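

In this assay the step of a 12-fold lower number from compound 2 to compound 4 (1.09 log units; beyond the scatter) shows that the number can move further through the group on this saturated chain carbon than the added methoxy had shown, and here it moves with 4-fluorophenyl in place of 3,4-dimethoxyphenyl, so no methoxy is needed for the lower number. The step of a 10-fold lower number from compound 1 to compound 4 (1.00 log units; beyond the scatter) gives the first difference beyond the scatter between a group attached through oxygen and one attached through nitrogen, yet compound 1 and compound 2 lie within the scatter of each other, so the nitrogen attachment alone does not bring the lower number. Compound 3 and compound 4 also lie within the scatter of each other, so two quite different rings reach the same level, and compound 2 stands apart from both.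

The compounds shown leave open whether the fluorine matters at all, since an unsubstituted benzyl group, a 4-chlorophenyl group or a pyridine ring at this place, or a longer chain between the ring and the nitrogen, could each settle how much of the step belongs to it. Nothing available here gives a reason for either step.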